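This account rests on a few compounds, and the source may have more. Where it says the series, first, only, none or still open, it means among the compounds named here.

Measured compounds:
compound 1, `CN(C)CCn1c(N)c(-c2nc3ccccc3[nH]2)c2nc(C#N)c(C#N)nc21`: > 50000 nM
compound 2, `CCN(CC)CCn1c(N)c(-c2nc3ccccc3[nH]2)c2nc(C#N)c(C#N)nc21`: > 50000 nM
compound 3, `CN(C)CCCCn1c(N)c(-c2nc3ccccc3o2)c2nc(C#N)c(C#N)nc21`: 5470 nM

All three were tested in a functional assay on A549 cells (Homo sapiens) for antiproliferative activity, read by MTT assay, with a stated time of 48 h; on this read-out higher numbers stand for weaker inhibition and lower numbers for stronger inhibition. Compound 1 gives > 50000 nM, which is a limit of the assay and not a number. Compound 2 likewise gives > 50000 nM, again a limit. The change between them is diethylamino in place of dimethylamino on a saturated chain carbon, two bonds along the chain from an aromatic nitrogen; the step that the two limits leave unreadable from compound 1 to compound 2 cannot be read, since both ends sit at the limit of > 50000 nM in this assay, at which 2 of the 3 values shown sit. Going by the values given here, compound 3 gives 5470 nM in this assay, the only numeric value in the set. The difference between the core of compound 1 and the core of compound 3 is not broken down here.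

Compound 4, `CCN(CC)CCCCn1c(N)c(-c2nc3ccccc3o2)c2nc(C#N)c(C#N)nc21`, is not yet measured. It differs from compound 3 by diethylamino in place of dimethylamino on a saturated chain carbon, four bonds along the chain from an aromatic nitrogen. This is the same kind of change as that from compound 1 to compound 2, but not the same: there the amine sits two bonds along the chain from an aromatic nitrogen, here four bonds along the chain from an aromatic nitrogen. Among the compounds with values here, the only earlier instance of this kind of change left no readable step, so there is little to rest on beyond the value of compound 3 itself. The step from compound 3 to compound 4 in this assay is expected to be small, a 1.0-fold higher number from compound 3 to compound 4 (0.00 log units; within the scatter), since the measured pair gave a step that the two limits leave unreadable from compound 1 to compound 2. Compound 4 is therefore estimated at 5500 nM in this assay, expected between 2500 nM and 12000 nM.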

Compound 4, half-maximal inhibitory concentration: 9390 nM
Compound 4: middle estimate off by 1.7-fold (0.23 log units), on the low side; low and high end bracket the measured number.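

In this assay, diethylamino in place of dimethylamino on a saturated chain carbon, four bonds along the chain from an aromatic nitrogen, gives a 1.7-fold higher number from compound 3 to compound 4 (0.23 log units; within the scatter), so on this core the two amines cannot be told apart in this read-out. Going by these compounds alone, the same change on the core of compound 1, two bonds along the chain from an aromatic nitrogen, gives no step that can be read, since compound 1 and compound 2 both sit at a limit of the assay and not at a number: the limit of > 50000 nM in this assay, at which 2 of the 4 values shown sit. This leaves a single readable instance of the change, which shows that it is tolerated on the core of compound 3 but not whether it would behave alike on another core, and the two pairs differ in chain position as well as in core.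

Still open, as far as these compounds go, is whether either amine, placed four bonds along the chain from an aromatic nitrogen on the core of compound 1, gives a number in this assay, and how the core of compound 3 reads with the amine two bonds along the chain. Also open, from the compounds shown here alone, is how a cyclic amine such as pyrrolidine or morpholine, or a chain longer than that of compound 3, would read in this assay.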